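The source may report more compounds than this note shows. Statements on the series, on what has been measured and on what is new or still open speak of the compounds shown alone.

Working notes on the series. Three compounds are measured in a functional assay on the whole organism for inhibition, with Brassica rapa subsp. chinensis as the target, with a stated time of 3 days, tested at 100 ppm; on this read-out lower numbers stand for less inhibition of growth and higher numbers for more inhibition of growth at the one concentration tested. Compound 1 `O=C(/C=C/c1ccccc1)NCc1ccccc1Cl` gives 88%. Compound 2 `O=C(/C=C/c1ccccc1)NCc1ccc(Cl)cc1Cl` gives 43%. Compound 3 `Cc1ccc(C(C)C)c(OC(=O)/C=C/c2ccc(Cl)cc2Cl)c1` gives 0%, the lowest of the three. Compound 1 and compound 2 share a core and differ in one place, (hydrogen in place of chloro on an aromatic carbon), and that step, a number 45 percentage points higher from compound 2 to compound 1 (beyond the scatter), is beyond the scatter. The cores of compound 2 and compound 3 are not the same, and the difference between them is not broken down here; what can be said is that compound 3 stands well below compound 2 in this assay.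

Compound 4 `Cc1ccc(C(C)C)c(OC(=O)/C=C/c2ccc(Cl)cc2)c1` has not been measured. Against compound 3 the change is hydrogen in place of chloro on an aromatic carbon. This is the same kind of change as that from compound 2 to compound 1, but not the same: in compound 1 the entering hydrogen sits meta to a chloro group and para to a large group, while in compound 4 it sits ortho to a large group and meta to a chloro group. Within the data shown here, the one measured instance of this kind of change is a rise, a number 45 percentage points higher from compound 2 to compound 1 (beyond the scatter), so a rise is expected here too, but it starts from compound 3 at 0% on a different core, so the size is uncertain. For compound 4 the estimated step is a number 20 percentage points higher from compound 3 to compound 4 (beyond the scatter). Compound 4 is expected to give 20%, between 0% and 55%.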

Compound 4, percent growth inhibition at one concentration: 24%
Beside the measured number, compound 4's estimate is 4 percentage points below it; measured number inside the range.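

In this assay the new step is a number 24 percentage points higher from compound 3 to compound 4 (beyond the scatter), so hydrogen in place of chloro on an aromatic carbon goes in the same direction on the second core, but its size does not carry over unchanged: the same change on two cores in this assay, a number 45 percentage points higher (beyond the scatter) from compound 2 to compound 1 and a number 24 percentage points higher (beyond the scatter) from compound 3 to compound 4, 21 percentage points apart, beyond the scatter of two such steps The direction therefore holds in both pairs shown, and no compound here goes against it, though two pairs do not make a rule for the series. The pairs differ in both core and place, with the change in compound 4 ortho to a large group and meta to a chloro group, so these data cannot show whether the core, the place or both set the difference in size.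

As far as these compounds go, it remains open how other groups at this aromatic carbon, such as a methoxy group, a nitrile or an amine, would read on either core. From the compounds shown here alone, it is also open what replacing the remaining chloro group with hydrogen would do in compound 1 or compound 4.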